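The source may report more compounds than this note shows. Statements on the series, on what has been measured and on what is new or still open speak of the compounds shown alone.

Compound 1 `CC(C)(C)c1nc(CCCCC#N)c2c(N)c(C#N)c(N)nc2n1`: 16000 nM
Compound 2 `CC(C)(C)c1nc(-c2ccsc2)c2c(N)c(C#N)c(N)nc2n1`: 40000 nM

In a physicochemical assay for solubility, in phosphate buffer, with a stated time of 18 h (a lower number here means a less soluble compound, a higher number a more soluble compound), compound 2 has the highest of the two numbers; its nearest neighbour is compound 1, reached by a 2.5-fold higher number from compound 1 to compound 2 (0.40 log units; beyond the scatter). Compound 3 `CC(C)(C)c1nc(-c2ncn[nH]2)c2c(N)c(C#N)c(N)nc2n1` differs from compound 2 by 1H-1,2,4-triazol-5-yl in place of thiophen-3-yl on an aromatic carbon. Among the compounds with values here, the one measured step, a 2.5-fold higher number from compound 1 to compound 2 (0.40 log units; beyond the scatter), concerns a different change and was only modest, so it gives weak guidance here; no measured pair covers an exchange of this kind. A modest upward step is nevertheless expected, a 2.0-fold higher number from compound 2 to compound 3 (0.30 log units; within the scatter). For compound 3 a value of 80000 nM is estimated, with a range from 25000 nM to 250000 nM.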

Compound 3, solubility: 64500 nM
The estimate for compound 3 lay 1.2-fold (0.09 log units) above the measured number; the measured number falls inside the stated range.
By their numbers in this assay, from the lowest: compound 1; then compounds 2 and 3 (each within the scatter of the next).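

In this assay, putting 1H-1,2,4-triazol-5-yl in place of thiophen-3-yl on this aromatic carbon gives a 1.6-fold higher number from compound 2 to compound 3 (0.21 log units; within the scatter), so this exchange of one five-membered aromatic ring for another, which adds 1 hydrogen-bond donor, does not separate the two compounds. Measured against the 4-cyanobutyl chain, the triazole gives a 4.0-fold higher number from compound 1 to compound 3 (0.61 log units; beyond the scatter), which shows that a second five-membered aromatic ring also stands apart from that chain. Nothing at hand accounts for these numbers. The compounds shown leave open how an amine, a carboxylic acid or a longer chain on this carbon would compare. They also leave open whether the same order would hold with another group in place of the tert-butyl group.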